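Chloro for nitro on the compound 1 scaffold

The source may hold more compounds than are shown below. What is called first, only, known or untested is meant among the compounds shown, and "the series" means these compounds.

Values measured in a functional assay on MGC-803 cells (Homo sapiens) for antiproliferative activity, read by MTT assay, with a stated time of 72 h (on this read-out higher numbers stand for weaker inhibition and lower numbers for stronger inhibition), so far:
- compound 1 `O=C1OCC[C@@H]1NC(=S)SCCOc1ccc([N+](=O)[O-])cc1` gives > 100000 nM (a limit)
- compound 2 `O=C(COc1ccc(C(=O)/C=C/c2ccc(F)c(F)c2)cc1)N[C@H]1CCOC1=O` gives > 64000 nM (a limit)
- compound 3 `COc1ccccc1/C=C/C(=O)c1ccc(OCC(=O)N[C@H]2CCOC2=O)cc1` gives 39400 nM (a number)

Compound 1 has no number, only the limit > 100000 nM in this read-out. Compound 2 is likewise reported only as a limit, so compound 3 alone has a measured number. The next compound is compound 4 `O=C1OCC[C@@H]1NC(=S)SCCOc1ccc(Cl)cc1`, with chloro in place of nitro on an aromatic carbon, para to a large group: chloro in place of nitro on an aromatic carbon is the whole change from the core of compound 1.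

Among the measured compounds shown here, no measured step covers this exchange. For the measured compounds named here, the one step available, an at least 1.6-fold lower number from compound 2 to compound 3 (0.21 log units; that floor lies within the scatter), replaces 3,4-difluorophenyl with 2-methoxyphenyl on compounds with a different core, and its floor lies within the scatter. It offers only weak support for expecting little movement, and it gives no direction for the exchange of nitro for chloro. In this assay no step beyond the scatter is therefore expected, and the estimate stays close to the limit of compound 1.

The expected change is a number no higher from compound 1 to compound 4 (the limit leaves the size open), and it should not be read as a real difference. For compound 4 the estimated value is 100000 nM, with an expected range from 35000 nM to 250000 nM, and a report as a limit alone is quite likely.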

Compound 4, half-maximal inhibitory concentration: 51100 nM
Beside the measured number, compound 4's estimate is 2.0-fold (0.29 log units) above it; measured number inside the range.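

In this assay, chloro in place of nitro on an aromatic carbon, para to a large group, turns a limit on the core of compound 1 into a measured number, and the step reads an at least 1.9-fold lower number from compound 1 to compound 4 (0.29 log units; that floor lies within the scatter). As far as these compounds go, the true size of this step stays open because compound 1 is reported only as a limit: the limit of > 100000 nM in this assay, at which 1 of the 4 values shown sits. Compound 4 now gives this core a measured reference point, so further exchanges at this aromatic carbon can be read against a number and not against a limit.

Among the compounds shown, this position carries only nitro and chloro, so it remains open how far the number depends on the group placed there, and an amine or a carboxylic acid at the same aromatic carbon would begin to answer that. From the compounds shown here alone, it is also open whether a longer chain in the linker of the core of compound 4 would shift the number in this read-out, and whether chloro in place of nitro would give a comparable step on another core.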